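Nitrofuran amides: cytotoxicity and a methylene insertion

The source may hold more compounds than are shown below. What is called first, only, known or untested is meant among the compounds shown, and "the series" means these compounds.

Compound 1, `CC(C)(NC(=O)c1ccc([N+](=O)[O-])o1)c1ccccc1`, in an ADME assay on Vero cells (Chlorocebus sabaeus) for cytotoxicity, read by MTT assay, with a stated time of 48 h (on this read-out higher numbers stand for lower toxicity in this test and lower numbers for higher toxicity in this test), gives > 180000 nM, a limit of the assay.
Compound 2, `CC(C)(NC(=O)c1ccc([N+](=O)[O-])o1)c1ccc(Cl)cc1`, in this assay gives 81000 nM.
Compound 3, `CC(C)(NC(=O)c1ccc([N+](=O)[O-])o1)c1ccc(Oc2ccc(Cl)cc2)cc1`, in this assay gives 67000 nM.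

Among the two numbers, compound 3 sits lowest, yet a 1.2-fold lower number from compound 2 to compound 3 (0.08 log units; within the scatter), so the pair is not ordered. Both differ from compound 1 beyond the scatter: an at least 2.2-fold lower number from compound 1 to compound 2 (0.34 log units; beyond the scatter) and an at least 2.6-fold lower number from compound 1 to compound 3 (0.42 log units; beyond the scatter). Compound 4, `CC(C)(NC(=O)c1ccc([N+](=O)[O-])o1)c1ccc(COc2ccc(Cl)cc2)cc1`, arises from compound 3 by (4-chlorophenoxy)methyl in place of 4-chlorophenoxy on an aromatic carbon. The step that bears on it is a 1.2-fold lower number from compound 2 to compound 3 (0.08 log units; within the scatter), where exchanging a small for a large group at this place changed little. Compound 4 is therefore expected to stay close, with a 1.1-fold lower number from compound 3 to compound 4 (0.05 log units; within the scatter). The estimate for compound 4 in this assay is 60000 nM, between 25000 nM and 150000 nM.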

Compound 4, half-maximal cytotoxic concentration: 120000 nM
The estimate for compound 4 lay 2.0-fold (0.30 log units) below the measured number, within the range that was stated.
By their numbers in this assay, from the lowest: compounds 3, 2 and 4 (each within the scatter of the next). At a limit, above all of these: compound 1.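

In this assay this position takes one more extension without a readable shift: (4-chlorophenoxy)methyl in place of 4-chlorophenoxy on an aromatic carbon gives a 1.8-fold higher number from compound 3 to compound 4 (0.25 log units; within the scatter), and (4-chlorophenoxy)methyl in place of chloro on an aromatic carbon gives a 1.5-fold higher number from compound 2 to compound 4 (0.17 log units; within the scatter). Chloro, 4-chlorophenoxy and (4-chlorophenoxy)methyl therefore stand unordered at this place. The remaining step, an at least 1.5-fold lower number from compound 1 to compound 4 (0.17 log units; that floor lies within the scatter), cannot be read, because the first of these two compounds stands at a limit of the assay: the limit of > 180000 nM in this assay, at which 1 of the 4 values shown sits. Going by these compounds, whether an amine, a carboxylic acid or a longer chain on this aromatic carbon would move the number beyond the scatter stays open.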